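Amine to amide on the outer five-membered ring

A few compounds are considered here, and "the series" means these few. Any claim that something is new, unique, unknown or untested is made for them only; others in the source may bear on it.

Compound 2 `CCCNCc1cc(-c2c(C(=O)NCC)noc2-c2cc(C(C)C)c(O)cc2O)on1` stands without a number in a functional assay on A2780 cells (Homo sapiens) for inhibition; on this read-out higher numbers stand for weaker inhibition and lower numbers for stronger inhibition; its result for compound 2 is recorded as "not determined" (no result reported). Its nearest measured relative is compound 1 `CCNCc1cc(-c2c(C(=O)NCC)noc2-c2cc(C(C)C)c(O)cc2O)on1`, which in this assay gives 45 nM. Compound 3 `CCNC(=O)c1noc(-c2cc(C(C)C)c(O)cc2O)c1-c1cc(C(N)=O)no1` carries carbamoyl where compound 1 carries (ethylamino)methyl, and in this assay compound 3 gives 15 nM; the step reads a 3.0-fold lower number from compound 1 to compound 3 (0.48 log units; beyond the scatter).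

Compound 4 `CCNC(=O)c1cc(-c2c(C(=O)NCC)noc2-c2cc(C(C)C)c(O)cc2O)on1` differs from compound 2 at one place: ethylcarbamoyl in place of (propylamino)methyl on an aromatic carbon Cut one bond further out, 3-((propylamino)methyl)-1,2-oxazol-5-yl becomes 3-(ethylcarbamoyl)-1,2-oxazol-5-yl.

For the measured compounds named here, the only step on record that bears on this change is the one from compound 1 to compound 3, a modest lowering of the number that lies beyond the scatter. A similar direction is expected here, though compound 2 itself gives no starting number, so the estimate rests on compound 3, beside which compound 4 carries ethylcarbamoyl where compound 3 carries carbamoyl. Compound 4 is therefore expected to land close to compound 3 in this assay, at 20 nM, within a range of 7 nM to 60 nM.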

Compound 4, half-maximal inhibitory concentration: 43 nM
Beside the measured number, compound 4's estimate is 2.2-fold (0.33 log units) below it, and the stated range covers the measured number.
By their numbers in this assay, from the lowest: compound 3; then compounds 4 and 1 (each within the scatter of the next).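

Amide nitrogen substitution matters at this position: in this assay ethyl on the amide-type nitrogen gives a 2.9-fold higher number from compound 3 to compound 4 (0.46 log units; beyond the scatter) and so takes away the advantage that carbamoyl showed in a 3.0-fold lower number from compound 1 to compound 3 (0.48 log units; beyond the scatter) over the amine. With an ethyl kept on the nitrogen, the amine-to-amide change itself gives a 1.0-fold lower number from compound 1 to compound 4 (0.02 log units; within the scatter) and so separates ethylcarbamoyl from (ethylamino)methyl by nothing beyond the usual variation in this assay. Nothing on hand accounts for either result.

The step from compound 2 to compound 4 cannot be read, as compound 2 has no number. Open, from the compounds shown here alone, is whether methylcarbamoyl, a longer chain such as propylcarbamoyl, or a carboxylic acid at this place would read closer to compound 3 or to compound 4.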